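The compounds below may be only part of what the source reports. "The series", "measured", "known", "first", "only" and "open" are said of these compounds alone.

Values so far in an ADME assay on the whole organism (plasma, strain CD1) for pharmacokinetics, with Mus musculus as the target, read by LC-MS, at a dose of 5 mg/kg by the oral route; a lower number here means less compound in the circulation, a higher number more compound in the circulation at the dose given

- compound 1 `Cc1c(Oc2cnc(C(=O)NC(C)CO)cn2)ccc2c1B(O)OC2` at 11100 nM
- compound 2 `Cc1c(Oc2cnc(C(=O)N[C@@H](CO)CC(F)(F)F)cn2)ccc2c1B(O)OC2` at 5110 nM

In this assay compound 2 holds the lower of the two numbers at 5110 nM. Among the compounds with values here, the one measured step, a 2.2-fold lower number from compound 1 to compound 2 (0.34 log units; beyond the scatter), is modest and came with 3,3,3-trifluoro-1-(hydroxymethyl)propyl in place of 1-(hydroxymethyl)ethyl on an amide-type nitrogen. Compound 3 `Cc1c(Oc2cnc(C(=O)N3CC(C)(O)C3)cn2)ccc2c1B(O)OC2` has 3-hydroxy-3-methylazetidin-1-yl in place of (3,3,3-trifluoro-1-(hydroxymethyl)propyl)amino on a carbonyl carbon. Within the data shown here, no measured step covers this ring, so the evidence is partial. Like compound 1 at 11100 nM, compound 3 carries no fluorine, which points to a modest rise. The expected change is a 1.6-fold higher number from compound 2 to compound 3 (0.19 log units; within the scatter), an estimate of about the size of the measured step in the opposite direction. The estimate for compound 3 is 8000 nM, with an expected range from 3000 nM to 20000 nM.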

Compound 3, maximal plasma concentration: 11000 nM
For compound 3 the middle estimate is 1.4-fold (0.14 log units) below the measured one; low and high end bracket the measured number.
By their numbers in this assay, from the lowest: compound 2; then compounds 3 and 1 (each within the scatter of the next).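

In this assay, 3-hydroxy-3-methylazetidin-1-yl on the carbonyl carbon brings a 2.2-fold higher number from compound 2 to compound 3 (0.33 log units; beyond the scatter), and set against (1-(hydroxymethyl)ethyl)amino it brings a 1.0-fold lower number from compound 1 to compound 3 (0.00 log units; within the scatter). Within the data shown here, the position therefore accepts a four-membered non-aromatic ring in place of an open chain with no difference beyond the scatter between compound 1 and compound 3, and compound 2, the only fluorinated compound of the three, stands apart from both. Nothing on hand accounts for these numbers.

As far as these compounds go, it remains open whether a trifluoromethyl group on the four-membered ring would give a step like the one seen with the open chain. Also open, from the compounds shown here alone, is how a 3-hydroxyazetidin-1-yl without the methyl, or a larger pyrrolidine ring, would read at this position.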